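A few compounds are considered here, and "the series" means these few. Any claim that something is new, unique, unknown or untested is made for them only; others in the source may bear on it.

Measured in a functional assay on CCRF-CEM cells (Homo sapiens) for antiproliferative activity, with a stated time of 72 h; a higher number here means a weaker inhibitor, a lower number a stronger inhibitor:
- Compound 1 `OC[C@H]1O[C@@H](n2cnc3c(NCc4ccccc4Cl)ncnc32)[C@H](O)[C@@H]1O`: 14500 nM
- Compound 2 `COc1cc(CNc2ncnc3c2ncn3[C@@H]2O[C@H](CO)[C@@H](O)[C@H]2O)cc(OC)c1`: > 166000 nM, a limit of the assay and not a number

Compound 2 therefore stands only at a limit (the limit of > 166000 nM in this assay, at which 1 of the 2 values shown sits). Compound 3 `Cc1cccc(CNc2ncnc3c2ncn3[C@@H]2O[C@H](CO)[C@@H](O)[C@H]2O)c1O` differs from it in one place (2-hydroxy-3-methylphenyl in place of 3,5-dimethoxyphenyl on a saturated chain carbon bound to a nitrogen on an aromatic ring), with 2-hydroxy-3-methylphenyl in place of 3,5-dimethoxyphenyl on a saturated chain carbon bound to a nitrogen on an aromatic ring. Within the data shown here, the one measured step bearing on this is an at least 11-fold higher number from compound 1 to compound 2 (1.05 log units; beyond the scatter), which brought in the group that compound 3 lacks. A large move to a lower number is therefore expected in this assay, and the estimated step is an at least 16-fold lower number from compound 2 to compound 3 (1.22 log units; beyond the scatter), although compound 3 has its own substituents. The estimate for compound 3 is 10000 nM, with an expected range from 1500 nM to 60000 nM.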

Compound 3, half-maximal inhibitory concentration: 900 nM
Estimate against measurement, compound 3: 11-fold (1.05 log units) above; the whole stated range lies above it.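

In this assay, among these compounds, the saturated chain carbon bound to a nitrogen on an aromatic ring proves able to carry a much stronger inhibitor than the earlier compounds showed: 2-hydroxy-3-methylphenyl gives an at least 180-fold lower number from compound 2 to compound 3 (2.26 log units; beyond the scatter) and a 16-fold lower number from compound 1 to compound 3 (1.21 log units; beyond the scatter). The first of these steps rests on a limit and not a number: the limit of > 166000 nM in this assay, at which 1 of the 3 values shown sits.

The hydroxy and the methyl enter together, so the compounds shown do not tell which of them carries the change. Nor do they show whether an amine in place of the hydroxy would keep it.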